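The source may report more compounds than this note shows. Statements on the series, on what has been measured and on what is new or still open speak of the compounds shown alone.

Going by the values given here, compound 2 `Cn1c(=O)c(S(=O)(=O)c2ccc(F)cc2F)cc2cnc(Nc3ccccn3)nc21` holds the highest of the two numbers so far: in a functional assay on DU-145 cells (Homo sapiens) for inhibition, read by trypan blue exclusion, with a stated time of 72 h (a higher number here means a weaker inhibitor, a lower number a stronger inhibitor), compound 2 gives 75000 nM. Compound 3 `Cn1c(=O)c(S(=O)(=O)c2ccc(F)cc2F)cc2cnc(Nc3cnc4[nH]ccc4c3)nc21` differs from compound 2 by a group of 9 heavy atoms (7 carbon, 2 nitrogen; one five-membered aromatic ring with 1 hetero atom, one six-membered aromatic ring with 1 hetero atom) in place of a group of 6 heavy atoms (5 carbon, 1 nitrogen; one six-membered aromatic ring with 1 hetero atom), on a nitrogen on an aromatic ring. Among the compounds with values here, the one measured step that bears on this change is a 15-fold higher number from compound 1 to compound 2 (1.18 log units; beyond the scatter), where compound 1 `Cn1c(=O)c(S(=O)(=O)c2ccc(F)cc2F)cc2cnc(Nc3ccc4cc[nH]c4c3)nc21` gave 5000 nM before its 1H-indol-6-yl was exchanged for pyridin-2-yl. Compound 3 restores a group with a five-membered and a six-membered aromatic ring, so a move back toward compound 1 is expected. Compound 3 is estimated at 6000 nM, between 2000 nM and 25000 nM, an expected step of a 13-fold lower number from compound 2 to compound 3 (1.10 log units; beyond the scatter).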

Compound 3, half-maximal inhibitory concentration: 750 nM
Estimate against measurement, compound 3: 8.0-fold (0.90 log units) above, outside the stated range (below it).
By their numbers in this assay, from the lowest: compound 3; then compound 1; then compound 2.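

In this assay, the group with a five-membered and a six-membered aromatic ring does more than recover what was lost with pyridin-2-yl: the change gives a 100-fold lower number from compound 2 to compound 3 (2.00 log units; beyond the scatter) and goes beyond the earlier best. Its six-membered ring now holds a hetero atom instead of being carbon only, and this comes with a 6.7-fold lower number from compound 1 to compound 3 (0.82 log units; beyond the scatter) at an equal heavy-atom count. No measurement here gives a reason for either step. From the compounds shown here alone, whether that ring nitrogen matters in another place remains open, and so does whether a morpholine or a simple amine on this nitrogen would keep any of the gain.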